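Chloro for bromo on the fused ring of compound 3

This account rests on a few compounds, and the source may have more. Where it says the series, first, only, none or still open, it means among the compounds named here.

Compound 3 `CCN(CC)CN1C(=O)C(=O)c2c(Br)cccc21` belongs to a set of three compounds measured in an ADME assay on MCF-10A cells (Homo sapiens) for cytotoxicity, read by sulforhodamine B assay, with a stated time of 48 h; on this read-out lower numbers stand for stronger inhibition of growth and higher numbers for weaker inhibition of growth. In this assay compound 3 gives 113000 nM, the highest of the three numbers. Its closest neighbour is compound 2 `CN(C)CN1C(=O)C(=O)c2c(Br)cccc21`, which in this assay gives 67800 nM; the step of a 1.7-fold higher number from compound 2 to compound 3 (0.22 log units; within the scatter). Furthest away stands compound 1 `Cc1ccc2nc(/N=C3\C(=O)N(CN(C)C)c4cccc(Br)c43)sc2c1`, which in this assay gives 21800 nM, a gap beyond the usual scatter.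

Compound 4 `CCN(CC)CN1C(=O)C(=O)c2c(Cl)cccc21` differs from compound 3 in one place: chloro in place of bromo on an aromatic carbon. For the measured compounds named here, none of the measured steps concerns a change of halogen. Going by the values given here, the only single-point step recorded, from dimethylamino to diethylamino, is a 1.7-fold higher number from compound 2 to compound 3 (0.22 log units; within the scatter) and stayed within the scatter, while compound 1 differs from compound 3 in several places at once and so says nothing about the bromo-to-chloro exchange on its own. Among the compounds with values here, with no step bearing directly on this change, the expectation is that the number for compound 4 remains close to that of compound 3, with no shift beyond the scatter in either direction.

Compound 4 is therefore estimated in this assay at 100000 nM, with a range from 45000 nM to 250000 nM, which amounts to an expected step of a 1.1-fold lower number from compound 3 to compound 4 (0.05 log units; within the scatter).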

Compound 4, concentration for 50% growth inhibition: 35000 nM
For compound 4 the middle estimate is 2.9-fold (0.46 log units) above the measured one, and the stated range ends above it.
By their numbers in this assay, from the lowest: compounds 1, 4, 2 and 3 (each within the scatter of the next, the first and the last beyond it).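

In this assay, the exchange of bromo for chloro, on an aromatic carbon of a six-membered aromatic ring of carbon only, gives a 3.2-fold lower number from compound 3 to compound 4 (0.51 log units; beyond the scatter). For the compounds shown here, it is the first change in one place in this set to go beyond the scatter, whereas the move from dimethylamino to diethylamino on the chain gave only a 1.7-fold higher number from compound 2 to compound 3 (0.22 log units; within the scatter), so the read-out responds to the identity of the halogen at this position in a way the earlier compounds could not reveal, though this rests on a single pair. No measurement offered here accounts for the difference between the two halogens.

The compounds shown leave open whether the same exchange would hold with the dimethylamino chain of compound 2 or on the core of compound 1, since a single pair cannot show whether the halogen step carries over to other partners. They also leave open how fluoro, iodo, a methyl group or a plain hydrogen on this aromatic carbon would fall relative to chloro and bromo, and so whether the halogens mark a trend or only an isolated difference.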